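The source may report more compounds than this note shows. Statements on the series, on what has been measured and on what is new or still open speak of the compounds shown alone.

Compound 1 `COc1ccc(/C=C\c2cc(OC)c(OC)c(OC)c2)cc1OCc1ccc(CN2CCCC[C@@H]2C(=O)O)cc1` gives in a functional assay on HepG2 cells (Homo sapiens) for antiproliferative activity, read by CCK-8 assay, with a stated time of 48 h (a higher number here means a weaker inhibitor, a lower number a stronger inhibitor), a value of > 10000 nM.
Compound 2 `COc1ccc(/C=C\c2cc(OC)c(OC)c(OC)c2)cc1OCc1ccc(CN[C@H](C(=O)O)[C@H](C)O)cc1` gives in this assay a value of > 10000 nM.

Both values are limits of this assay rather than numbers, so compound 2 stands at the limit where (the limit of > 10000 nM in this assay, at which 2 of the 2 values shown sit), and nothing separates it from compound 1 on the numbers shown. Going by the values given here, the only measured step, a step that the two limits leave unreadable from compound 1 to compound 2, is therefore unreadable in size and direction.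

Compound 3 `COc1ccc(/C=C\c2cc(OC)c(OC)c(OC)c2)cc1OCc1ccc(CNCCNC(C)=O)cc1` differs from compound 2 by 2-acetamidoethyl in place of 1-carboxy-2-hydroxypropyl on an amine nitrogen. The measured step that bears on this change, from compound 1 to compound 2, gives no readable size, so no direction can be taken from it, and no step beyond the scatter is expected in this assay; the expected step is a number no higher from compound 2 to compound 3 (the limit leaves the size open). Compound 3 is accordingly estimated to stand near the same limit, at 10000 nM, within a range from 2000 nM to 50000 nM, with a fair chance that this assay again reports only a limit.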

Compound 3, half-maximal inhibitory concentration: 6100 nM
Beside the measured number, compound 3's estimate is 1.6-fold (0.21 log units) above it, and the stated range covers the measured number.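

In this assay compound 3 is the only one of the three to give a number rather than a limit, so this position on the amine nitrogen can carry a substituent that yields a measurable reading. Going by these compounds, the change to 2-acetamidoethyl gives an at least 1.6-fold lower number from compound 2 to compound 3 (0.21 log units; that floor lies within the scatter), and the wider change at the same place gives an at least 1.6-fold lower number from compound 1 to compound 3 (0.21 log units; that floor lies within the scatter); each is only a floor, so the true size of both steps stays open. The other two compounds, which both carry a carboxylic acid, remain at a limit: the limit of > 10000 nM in this assay, at which 2 of the 3 values shown sit.

The compounds shown leave open whether losing the carboxylic acid or adding the acetamide accounts for the reading. A plain ethylamine, a longer chain ending in the acetamide, or a chain ending in a hydroxyl at this nitrogen could separate the two.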